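This account rests on a few compounds, and the source may have more. Where it says the series, first, only, none or still open, it means among the compounds named here.

Measured compounds, with their values in a functional assay on CHO cells for agonist activity at Alpha-1A adrenergic receptor (Homo sapiens), read by FLIPR and calcium flux; a higher number here means that more compound is needed for the effect, a lower number that less compound is needed:
compound 1, `c1ccc2c(c1)CCC2c1ncc[nH]1`: 473 nM
compound 2, `c1cc(-c2ncco2)c2c(c1)C(c1ncc[nH]1)CC2`: 170 nM

Compound 2 shows the lower of the two numbers. For the measured compounds named here, its nearest neighbour is compound 1, and the single step between them, a 2.8-fold lower number from compound 1 to compound 2 (0.44 log units; beyond the scatter), comes from putting a 1,3-oxazol-2-yl group onto the core in place of hydrogen. Compound 3, `c1cc(-c2nccs2)c2c(c1)C(c1ncc[nH]1)CC2`, keeps that substituted core and changes only the ring on the aromatic carbon: 1,3-thiazol-2-yl in place of 1,3-oxazol-2-yl on an aromatic carbon. Going by the values given here, no measured step covers such a swap of one five-membered aromatic ring for another; the one step available describes the gain of the ring, not its identity. The step from compound 2 to compound 3 is therefore expected to stay within the scatter, a 1.1-fold lower number from compound 2 to compound 3 (0.05 log units; within the scatter). For compound 3 the estimated value in this assay is 150 nM, with a range from 60 nM to 400 nM.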

Compound 3, half-maximal effective concentration: 426 nM
Compound 3: the middle estimate sits 2.8-fold (0.45 log units) below what was measured; the measured number lies above the stated range.
By their numbers in this assay, from the lowest: compound 2; then compounds 3 and 1 (each within the scatter of the next).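

In this assay, the result shows that what counts at this aromatic carbon is which ring sits there, not merely that a five-membered aromatic ring is present: with the same count of heavy atoms and sulfur in place of oxygen, the change gives a clear step (a 2.5-fold higher number from compound 2 to compound 3 (0.40 log units; beyond the scatter)). The gain seen on adding 1,3-oxazol-2-yl (a 2.8-fold lower number from compound 1 to compound 2 (0.44 log units; beyond the scatter)) does not carry over to 1,3-thiazol-2-yl, which leaves compound 3 indistinguishable from the unsubstituted compound (a 1.1-fold lower number from compound 1 to compound 3 (0.05 log units; within the scatter)). Nothing available accounts for this difference between the two rings.

On these data alone, whether the lower number of compound 2 is particular to 1,3-oxazol-2-yl remains open, since no phenyl or imidazolyl group appears at this carbon. Also open, as far as these compounds go, is how a methyl group on the oxazole ring would affect the number.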